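From 3-chlorophenyl to 3,4-dichlorophenyl: one added chloro

The source may hold more compounds than are shown below. What is called first, only, known or untested is meant among the compounds shown, and "the series" means these compounds.

Compound 1 (`O=C1CC(c2ccc(NC(=O)Nc3ccc(Cl)c(C(F)(F)F)c3)cc2)=Nc2cn[nH]c2N1`) gives (> 30000 nM)
Compound 2 (`COc1ccc(Cn2ncc3c2NC(=O)CC(c2cccc(NC(=O)Nc4cccc(Cl)c4)c2)=N3)cc1`) gives (910 nM)

Both compounds were tested in a functional assay on A375P cells (Homo sapiens) for inhibition, read by MTT assay, with a stated time of 24 h (on this read-out lower numbers stand for stronger inhibition of growth and higher numbers for weaker inhibition of growth), and gave the results above. The result for compound 1 (> 30000 nM) is a limit of the assay, not a number. For the measured compounds named here, that leaves compound 2 (910 nM) with the only true number in the set.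

Compound 3 (`COc1ccc(Cn2ncc3c2NC(=O)CC(c2cccc(NC(=O)Nc4ccc(Cl)c(Cl)c4)c2)=N3)cc1`) carries one change from compound 2 (chloro in place of hydrogen on an aromatic carbon): chloro in place of hydrogen on an aromatic carbon, which turns 3-chlorophenyl into 3,4-dichlorophenyl. Going by the values given here, no measured pair shows this change. In this assay, the expected step (a 1.5-fold lower number from compound 2 to compound 3 (0.18 log units; within the scatter)) is small, towards stronger inhibition of growth, and is not expected to go beyond the usual scatter. Compound 3 is estimated at (600 nM), within an expected range from (200 nM) to (1800 nM).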

Compound 3, concentration for 50% growth inhibition: 3860 nM
The estimate for compound 3 lay 6.4-fold (0.81 log units) below the measured number; measured number outside the range, above it.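

In this assay, placing a chloro on the aromatic carbon ortho to a chloro group and para to a large group, the change from 3-chlorophenyl to 3,4-dichlorophenyl, gives a 4.2-fold higher number from compound 2 to compound 3 (0.63 log units; beyond the scatter) and so weakens inhibition of growth. For the compounds shown here, this single pair is the first reading at this position, and it shows that one added chlorine atom there is enough to move the result beyond the scatter, towards weaker inhibition. Nothing given here explains the direction or size of this step.

The pair cannot tell whether the weakening belongs to chloro in particular or to any group on this carbon. As far as these compounds go, how a fluoro or an amine at the same place would read remains open, as does whether the same step would appear with the chloro of compound 2 absent.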